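Swapping the Azepane Ring for a Methylpiperazine

This account rests on a few compounds, and the source may have more. Where it says the series, first, only, none or still open, it means among the compounds named here.

Compound 1 `Clc1ccc2c(NCCN3CCCCCC3)ccnc2c1` gives 13200 nM
Compound 2 `Clc1ccc2c(NCCNCCN3CCCCCC3)ccnc2c1` gives 76100 nM

Going by the values given here, both values come from a toxicity assay (L6 cells) for inhibition, with Rattus norvegicus as the target, read by resazurin assay, with a stated time of 70 h (on this read-out lower numbers stand for stronger inhibition and higher numbers for weaker inhibition), and they are the only two numbers available. Compound 1 holds the lower number and so shows the stronger inhibition of the pair, with compound 2 at 76100 nM lying beyond the usual scatter of repeated measurements.

Compound 3 `CN1CCN(CCNc2ccnc3cc(Cl)ccc23)CC1` has not yet been measured. It differs from compound 1 in one place: 4-methylpiperazin-1-yl in place of azepan-1-yl on a saturated chain carbon, two bonds along the chain from a nitrogen on an aromatic ring. In words, this is 4-methylpiperazin-1-yl in place of azepan-1-yl on a saturated chain carbon, two bonds along the chain from a nitrogen on an aromatic ring.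

Among the compounds with values here, no measured pair shows this change directly, so any forecast rests on thin evidence. Since compound 1 at 13200 nM already holds the lower of the two numbers, a moderate step towards weaker inhibition is expected in this assay, only slightly beyond the scatter. The estimated move is a 2.3-fold higher number from compound 1 to compound 3 (0.36 log units; beyond the scatter) and could prove smaller. For compound 3 the estimated value is 30000 nM, with an expected range from 11000 nM to 80000 nM.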

Compound 3, half-maximal inhibitory concentration: 16700 nM
For compound 3 the middle estimate is 1.8-fold (0.25 log units) above the measured one; the range from low to high includes it.
By their numbers in this assay, from the lowest: compounds 1 and 3 (each within the scatter of the next); then compound 2.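

In this assay, exchanging azepan-1-yl for 4-methylpiperazin-1-yl gives a 1.3-fold higher number from compound 1 to compound 3 (0.10 log units; within the scatter). Going by these compounds alone, this is the first direct reading of a change at this position, and it shows that a one-for-one exchange of these two rings of equal heavy-atom count leaves the number within the usual scatter, even though the six-membered ring brings 2 hetero atoms and 2 hydrogen-bond acceptors where the seven-membered ring had 1 of each. No measured property of either group bears on this result, so the data give no explanation for it.

From the compounds shown here alone, a single exchange cannot show how far this tolerance extends, and it remains open whether a morpholine, a piperidine or an open-chain dimethylamino group at the same place would also stay within the scatter. Going by these compounds, it is equally open whether 4-methylpiperazin-1-yl would read the same way on the longer chain of compound 2, or whether a free piperazine without its methyl group would match compound 3.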